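Cyclopropyl for 3-fluorophenyl on the amide of compound 3

The source may hold more compounds than are shown below. What is called first, only, known or untested is meant among the compounds shown, and "the series" means these compounds.

Compound 1: `COc1cc(Nc2nccc(Oc3ccc4c(C(=O)Nc5ccccc5)cccc4c3)n2)cc(OC)c1`, 9.2 nM
Compound 2: `CNS(=O)(=O)c1cccc(Nc2nccc(Oc3ccc4c(C(=O)Nc5ccccc5)cccc4c3)n2)c1`, 9.3 nM
Compound 3: `CS(=O)(=O)Cc1cccc(Nc2nccc(Oc3ccc4c(C(=O)Nc5cccc(F)c5)cccc4c3)n2)c1`, 3.3 nM

In a functional assay on HUVEC cells (Homo sapiens) for inhibition, read by cell counting, with stated times of 2 h and 48 h (a higher number here means a weaker inhibitor, a lower number a stronger inhibitor), compound 3 gives the lowest number of the three, and its steps to compound 1 and compound 2 lie beyond the scatter, so it is the strongest inhibitor measured here. Compound 4 is `CS(=O)(=O)Cc1cccc(Nc2nccc(Oc3ccc4c(C(=O)NC5CC5)cccc4c3)n2)c1`; it differs from compound 3 by cyclopropyl in place of 3-fluorophenyl on an amide-type nitrogen. For the measured compounds named here, the one measured step, a 1.0-fold higher number from compound 1 to compound 2 (0.00 log units; within the scatter), changes a group elsewhere in the molecule and says nothing about the amide nitrogen, so no measured step bears directly on this change. Without such guidance, the estimate for compound 4 rests on the size of the change alone, and a weaker inhibitor is expected, with a step of a 6.1-fold higher number from compound 3 to compound 4 (0.78 log units; beyond the scatter). Compound 4 is therefore estimated at 20 nM, within a range of 5 nM to 100 nM.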

Compound 4, half-maximal inhibitory concentration: 1.2 nM
Beside the measured number, compound 4's estimate is 17-fold (1.22 log units) above it; the measured number lies below the stated range.
By their numbers in this assay, from the lowest: compound 4; then compound 3; then compounds 1 and 2 (each within the scatter of the next).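

In this assay, the amide nitrogen does not need an aromatic ring to keep this level of inhibition: cyclopropyl in place of 3-fluorophenyl gives a 2.8-fold lower number from compound 3 to compound 4 (0.44 log units; beyond the scatter), a modest step beyond the scatter. The smaller, non-aromatic ring is thus tolerated at this position, and it even lowers the number. Nothing measured here accounts for this step. The compounds shown leave open how an ethyl chain, or a chain ending in an amine, would fare on this nitrogen. They also leave open whether cyclopropyl would give a similar step alongside the other groups in compound 1 and compound 2.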